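A Fluoro-Methoxy Swap on the Aryl Group

The compounds below may be only part of what the source reports. "The series", "measured", "known", "first", "only" and "open" are said of these compounds alone.

Values in an ADME assay on HepG2 2.2.15 cells (Homo sapiens) for cytotoxicity, read by CCK-8 assay, with a stated time of 8 days (on this read-out higher numbers stand for lower toxicity in this test and lower numbers for higher toxicity in this test), for the measured compounds:

- Compound 1 `COc1ccc(-c2cc(NC(=O)c3ccc(OC)cc3O)c[nH]c2=O)cc1` gives 49900 nM
- Compound 2 `COc1ccc(C(=O)Nc2c[nH]c(=O)c(-c3cccc(C)c3)c2)c(O)c1` gives > 100000 nM
- Compound 3 `COc1ccc(C(=O)Nc2c[nH]c(=O)c(-c3ccc(C)c(C)c3)c2)c(O)c1` gives 31300 nM

The value for compound 2 is a limit of the assay and not a number. Among the measured compounds shown here, that leaves compound 1 as the only numerical comparison for compound 3, and the two lie within the scatter of each other: a 1.6-fold lower number from compound 1 to compound 3 (0.20 log units; within the scatter).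

Compound 4 `COc1ccc(C(=O)Nc2c[nH]c(=O)c(-c3ccc(OC)c(F)c3)c2)c(O)c1` has not yet been measured. It carries 3-fluoro-4-methoxyphenyl in place of 3,4-dimethylphenyl on an aromatic carbon.

All three measured steps involve a change in the group at this same place. The first is a 1.6-fold lower number from compound 1 to compound 3 (0.20 log units; within the scatter), where 3,4-dimethylphenyl replaces 4-methoxyphenyl. The second is an at least 2.0-fold higher number from compound 1 to compound 2 (0.30 log units; that floor lies within the scatter), and its floor also lies within the scatter. The third is an at least 3.1-fold lower number from compound 2 to compound 3 (0.50 log units; beyond the scatter), which shows that a single added methyl can take the number beyond the scatter, so a larger move in this assay cannot be ruled out. Even so, the closest precedent stays within the scatter, and a step of similar size is expected, tilted slightly upward. The expected step is a 1.4-fold higher number from compound 3 to compound 4 (0.16 log units; within the scatter), which would not go beyond the scatter. Compound 4 is estimated at 45000 nM, with an expected range from 20000 nM to 100000 nM.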

Compound 4, half-maximal cytotoxic concentration: 50500 nM
Compound 4: the middle estimate sits 1.1-fold (0.05 log units) below what was measured; measured number inside the range.
By their numbers in this assay, from the lowest: compounds 3, 1 and 4 (each within the scatter of the next). At a limit, above all of these: compound 2.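

In this assay, 3-fluoro-4-methoxyphenyl in place of 3,4-dimethylphenyl gives a 1.6-fold higher number from compound 3 to compound 4 (0.21 log units; within the scatter), so at this position a group with 1 hydrogen-bond acceptor, where the group it replaces has 0, stays within the scatter. Among the compounds shown here, no earlier pair showed fluoro in place of hydrogen on this aryl group, and here it gives a 1.0-fold higher number from compound 1 to compound 4 (0.01 log units; within the scatter), which places that single addition within the scatter as well. The third step, an at least 1.9-fold lower number from compound 2 to compound 4 (0.29 log units; that floor lies within the scatter), is only a floor, set by a limit of the assay and not a number: the limit of > 100000 nM in this assay, at which 1 of the 4 values shown sits.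

The compounds shown carry only methyl, methoxy and fluoro on this aryl group, so it stays open how an amine, a carboxylic acid or a longer chain at this position would read in this assay. From the compounds shown here alone, it also stays open whether fluoro in place of hydrogen would remain within the scatter on an aryl group other than 4-methoxyphenyl.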